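The source may report more compounds than this note shows. Statements on the series, on what has been measured and on what is new or still open speak of the compounds shown alone.

Compound 1 `CC1=C(N2CC2)C(=O)C(CCCOC(N)=O)=C(N2CC2)C1=O` belongs to a series of three aziridinyl quinone carbamates tested in a functional assay on L1210 cells (Mus musculus), with a stated time of 12 days; on this read-out lower numbers stand for lower potency and higher numbers for higher potency (the scale is a negative logarithm). In this assay compound 1 gives 6.18. Its neighbours are compound 2 `CCC1=C(N2CC2)C(=O)C(C(COC(N)=O)OC)=C(N2CC2)C1=O`, which gives 6.16, and compound 3 `CCC1=C(N2CC2)C(=O)C(CCOC(N)=O)=C(N2CC2)C1=O`, which gives 6.25; compound 1 sits second of the three numbers, and all three lie within the scatter of one another.

Compound 4 `CCC(OC)C1=C(N2CC2)C(=O)C(C)=C(N2CC2)C1=O` has not yet been measured. It differs from compound 1 by a group of 5 heavy atoms (4 carbon, 1 oxygen; no ring) in place of a group of 7 heavy atoms (4 carbon, 1 nitrogen, 2 oxygen; no ring), on a double-bonded ring carbon. Among the compounds with values here, only one measured step touches any part of this change: the removal of a methoxy from a saturated chain carbon, a number 0.09 log units higher from compound 2 to compound 3 (within the scatter), which lies within the scatter. Within the data shown here, no measured step covers the loss of the carbamate-bearing chain itself, the part that carries the hydrogen-bond donor. Without such a step, the outcome is uncertain, and the expectation is a moderate fall, a number 0.48 log units lower from compound 1 to compound 4 (beyond the scatter), with a wide range. Compound 4 is therefore estimated at 5.7, between 5 and 6.4.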

Compound 4, logarithm of the reciprocal of the active concentration, log(1/C): 5.68
The estimate for compound 4 lay 0.02 log units above the measured number; measured number inside the range.
By their numbers in this assay, from the lowest: compound 4; then compounds 2, 1 and 3 (each within the scatter of the next).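

In this assay, within the data shown here, the one change on the double-bonded ring carbon that puts 1-methoxypropyl in place of the carbamate-bearing chain gives the first step that lies beyond the scatter: a number 0.50 log units lower from compound 1 to compound 4 (beyond the scatter). The earlier step, a number 0.09 log units higher from compound 2 to compound 3 (within the scatter), touched only a methoxy on the chain and stayed within the scatter, whereas this one shows that the group at this position can move the number while the rest of compound 1 stays the same. No measurement shown here explains this fall.

Going by these compounds, it remains open whether a chain ending in hydroxyl instead of the carbamate would stay level with compound 1 or fall as far as compound 4. On these data alone, how an amine, a carboxylic acid or a longer chain at this position would read is also open.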